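A few compounds are considered here, and "the series" means these few. Any claim that something is new, unique, unknown or untested is made for them only; others in the source may bear on it.

In a functional assay on HepG2 cells (Homo sapiens) for antiproliferative activity, read by MTT assay, with a stated time of 24 h (on this read-out lower numbers stand for stronger inhibition and higher numbers for weaker inhibition), compound 1 `Cc1ccccc1-n1cc(-c2ccccc2NS(=O)(=O)c2c[nH]c(=O)[nH]c2=O)nn1` gives 13900 nM, and compound 2 `Cc1cccc(-n2cc(-c3ccccc3NS(=O)(=O)c3c[nH]c(=O)[nH]c3=O)nn2)c1` gives 3620 nM, the lowest of the two numbers measured. Among the measured compounds shown here, the only step so far, a 3.8-fold lower number from compound 1 to compound 2 (0.58 log units; beyond the scatter), came with a 3-methylphenyl in place of a 2-methylphenyl. Compound 3 `O=c1[nH]cc(S(=O)(=O)Nc2ccccc2-c2cn(-c3ccccc3F)nn2)c(=O)[nH]1` carries the change (2-fluorophenyl in place of 3-methylphenyl on an aromatic nitrogen). Like the 2-methylphenyl of compound 1, the entering 2-fluorophenyl is named with the same number, so a modest rise in this assay is expected because a 3.8-fold lower number from compound 1 to compound 2 (0.58 log units; beyond the scatter) ran the other way. Compound 3 is estimated at 7500 nM, within 2500 nM to 22000 nM. That estimate means a 2.1-fold higher number from compound 2 to compound 3 (0.32 log units; beyond the scatter).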

Compound 3, half-maximal inhibitory concentration: 12500 nM
Estimate against measurement, compound 3: 1.7-fold (0.22 log units) below, within the range that was stated.
By their numbers in this assay, from the lowest: compound 2; then compounds 3 and 1 (each within the scatter of the next).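

Changing the 3-methylphenyl to a 2-fluorophenyl gives a 3.5-fold higher number from compound 2 to compound 3 (0.54 log units; beyond the scatter), so the lower number of compound 2 does not carry over to this group. Fluoro in place of methyl on an aromatic carbon gives a 1.1-fold lower number from compound 1 to compound 3 (0.05 log units; within the scatter), which leaves compound 2 alone apart from the other two compounds. Nothing measured here explains the difference. Still open, going by these compounds, is how a plain phenyl, or a phenyl carrying an amine or a carboxylic acid, would compare at this aromatic nitrogen.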